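This account rests on a few compounds, and the source may have more. Where it says the series, first, only, none or still open, it means among the compounds named here.

Measured so far:
compound 1, `COc1ccc(OC)c(-c2cc(-c3ccccc3)nn2-c2ccc(S(N)(=O)=O)cc2)c1`, 12300 nM
compound 2, `Oc1ccc(O)c(-c2cc(-c3ccccc3)nn2-c2ccccc2)c1`, 17100 nM

Both compounds were tested in a functional assay on cells (Cancer cell lines, Homo sapiens) for cytotoxicity, read by sulforhodamine B assay, with a stated time of 48 h; on this read-out higher numbers stand for weaker inhibition of growth and lower numbers for stronger inhibition of growth. In this assay compound 1 gives 12300 nM, and compound 2 gives 17100 nM. Compound 2 sits at one end of the two numbers, but compound 1 lies so close to it that the gap between the two falls within the usual scatter of repeated measurements; the two numbers therefore cannot be told apart with confidence.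

Compound 3, `NS(=O)(=O)c1ccc(-n2nc(-c3ccccc3)cc2-c2cc(O)ccc2O)cc1`, has not yet been measured. Compared with compound 2 it carries one change: sulfamoyl in place of hydrogen on an aromatic carbon. For the measured compounds named here, no step between two measured compounds shows what this single change does by itself. Compound 1 differs from compound 2 in more than one place. Going by the values given here, the only guide is that compound 1, which carries the sulfamoyl group, and compound 2, which does not, give numbers within the scatter of each other.

On that basis compound 3 is expected to stay close to compound 2, with an estimated step of a 1.4-fold lower number from compound 2 to compound 3 (0.15 log units; within the scatter), not beyond the scatter. The estimate for compound 3 is 12000 nM, with a range from 4000 nM to 36000 nM.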

Compound 3, concentration for 50% growth inhibition: 83900 nM
Estimate against measurement, compound 3: 7.0-fold (0.84 log units) below; the whole stated range lies below it.
By their numbers in this assay, from the lowest: compounds 1 and 2 (each within the scatter of the next); then compound 3.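

In this assay, for the compounds shown here, sulfamoyl in place of hydrogen on an aromatic carbon, para to a large group, gives the first reading of this single change (a 4.9-fold higher number from compound 2 to compound 3 (0.69 log units; beyond the scatter)), so with the 2,5-dihydroxyphenyl group present, this position is sensitive to the change and growth inhibition is weaker. Swapping 2,5-dimethoxyphenyl for 2,5-dihydroxyphenyl while sulfamoyl stays in place also weakens growth inhibition (a 6.8-fold higher number from compound 1 to compound 3 (0.83 log units; beyond the scatter)), which shows that the closeness of compound 1 and compound 2 did not mean that these two changes are without consequence, since those two compounds differ in more than one place and only compound 3 separates the changes. Nothing measured here gives a reason for either step.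

Whether the sulfamoyl step depends on the neighbouring aryl group stays open, since the compounds shown do not pair 2,5-dimethoxyphenyl with hydrogen at this position, and so the same swap cannot be read without sulfamoyl. On these data alone, it also remains open whether a smaller or different group at this place, such as an amine or a carboxylic acid, would give a step of similar size.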